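The source may hold more compounds than are shown below. What is called first, only, known or untested is meant among the compounds shown, and "the series" means these compounds.

Measured in a physicochemical assay for lipophilicity, read by HPLC, at pH 7.5 (on this read-out higher numbers stand for higher lipophilicity and lower numbers for lower lipophilicity), so far:
- compound 1 `CCOc1ccccc1-c1ccc(-c2nc3cnccc3cc2C#N)cc1` gives 3.8
- compound 2 `CCOc1ccccc1-c1ccc(-c2nc3cnccc3c(N[C@H](CC)C(=O)O)c2C#N)cc1` gives 2.1

Compound 2 holds the lower of the two numbers. Going by the values given here, in compound 3 `CCOc1ccccc1-c1ccc(-c2nc3cnccc3c(NC(CC)CNS(=O)(=O)C3CC3)c2C#N)cc1` the change is a group of 11 heavy atoms (7 carbon, 1 nitrogen, 2 oxygen, 1 sulfur; one three-membered non-aromatic ring of carbon only) in place of a group of 6 heavy atoms (4 carbon, 2 oxygen; no ring), on a nitrogen on an aromatic ring, and no measured step covers it directly. Among the compounds with values here, the only step bearing on it is a number 1.70 log units lower from compound 1 to compound 2 (beyond the scatter), with (1-carboxypropyl)amino in place of hydrogen on an aromatic carbon. Compound 3 no longer carries the 1-carboxypropyl, so most of that large step is expected to return. The expected step is a number 1.50 log units higher from compound 2 to compound 3 (beyond the scatter), large and upward in this assay. For compound 3 the estimated value is 3.6 (expected range 3.1 to 4.1).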

Compound 3, distribution coefficient: 3.6
Beside the measured number, compound 3's estimate shows no gap at the digits printed; measured number inside the range.
By their numbers in this assay, from the lowest: compound 2; then compounds 3 and 1 (each within the scatter of the next).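

Substitution on this nitrogen need not hold the number down: in this assay the exchange of 1-carboxypropyl for the group with the three-membered carbon ring gives a number 1.50 log units higher from compound 2 to compound 3 (beyond the scatter) in this series. Against the unsubstituted core, the same group gives a number 0.20 log units lower from compound 1 to compound 3 (within the scatter), so the large drop is confined to the 1-carboxypropyl compound among these three. No measurement available here bears on the reason for this difference.

Open, going by these compounds, is how an amine or a longer chain in place of the three-membered carbon ring would read. Also open, on these data alone, is whether the two mirror-image forms of compound 3 would read alike.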